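Longer Chain, Larger Amine: Estimating Compound 4

The source may hold more compounds than are shown below. What is called first, only, known or untested is meant among the compounds shown, and "the series" means these compounds.

Three compounds share one core and differ only in the amine-bearing side chain. Compound 1 `CN(C)CCCn1c(N)c(-c2nc3cc(Cl)ccc3[nH]2)c2nc(C#N)c(C#N)nc21` gives 5310 nM in a functional assay on HL60/MX2 cells (Homo sapiens) for antiproliferative activity, read by MTT assay, with a stated time of 48 h; a lower number here means a stronger inhibitor, a higher number a weaker inhibitor. Compound 2 `CCN(CC)CCCn1c(N)c(-c2nc3cc(Cl)ccc3[nH]2)c2nc(C#N)c(C#N)nc21` gives 2460 nM in this assay, and compound 3 `CN(C)CCCCn1c(N)c(-c2nc3cc(Cl)ccc3[nH]2)c2nc(C#N)c(C#N)nc21` gives 580 nM. The change from compound 1 to compound 2 is diethylamino in place of dimethylamino on a saturated chain carbon, three bonds along the chain from an aromatic nitrogen, and it gave a 2.2-fold lower number from compound 1 to compound 2 (0.33 log units; beyond the scatter). Compound 3 differs from compound 1 by (dimethylamino)methyl in place of dimethylamino on a saturated chain carbon, three bonds along the chain from an aromatic nitrogen, with a 9.2-fold lower number from compound 1 to compound 3 (0.96 log units; beyond the scatter). Compound 4 `CCN(CC)CCCCn1c(N)c(-c2nc3cc(Cl)ccc3[nH]2)c2nc(C#N)c(C#N)nc21` is not yet measured; it differs from compound 3 by diethylamino in place of dimethylamino on a saturated chain carbon, four bonds along the chain from an aromatic nitrogen. This is the same kind of change as from compound 1 to compound 2, but the place differs: three bonds along the chain from an aromatic nitrogen there, four bonds here. Because compound 1 to compound 2 gave a 2.2-fold lower number from compound 1 to compound 2 (0.33 log units; beyond the scatter), a similar step is expected, a 2.1-fold lower number from compound 3 to compound 4 (0.33 log units; beyond the scatter). Compound 4 is thus estimated at 270 nM, between 110 nM and 700 nM.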

Compound 4, half-maximal inhibitory concentration: 1770 nM
For compound 4 the middle estimate is 6.6-fold (0.82 log units) below the measured one, outside the stated range (above it).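

The swap of dimethylamino for diethylamino does not carry over from one core to the other in this series, and its direction reverses on the longer chain: the same change on two cores in this assay, a 2.2-fold lower number (0.33 log units; beyond the scatter) from compound 1 to compound 2 and a 3.1-fold higher number (0.48 log units; beyond the scatter) from compound 3 to compound 4, 6.6-fold (0.82 log units) apart, beyond the scatter of two such steps On the longer chain the swap gives a 3.1-fold higher number from compound 3 to compound 4 (0.48 log units; beyond the scatter), while lengthening the chain with diethylamino in place gives a 1.4-fold lower number from compound 2 to compound 4 (0.14 log units; within the scatter), which lies within the scatter, and the change with both differences together gives a 3.0-fold lower number from compound 1 to compound 4 (0.48 log units; beyond the scatter). These two pairs show that the step depends on the core, but they do not show why it reverses or how general the reversal is.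

As far as these compounds go, whether a piperidine or a still longer chain would follow compound 3 or compound 4 stays open.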